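Removing the Nitro Group from an Aryl Urea

A few compounds are considered here, and "the series" means these few. Any claim that something is new, unique, unknown or untested is made for them only; others in the source may bear on it.

For compound 1 `COc1ccc(-c2c(Cl)c(=O)c3c(OC)cc(OC)cc3n2S(=O)(=O)c2ccc(OC)cc2)cc1` the entry in a functional assay on HepG2 cells (Homo sapiens) for antiproliferative activity, with a stated time of 72 h (on this read-out lower numbers stand for an effect already at smaller amounts and higher numbers for an effect only at larger amounts of compound), reads "not determined" (no result reported), so no result was reported.
Compound 2 `COc1ccc(-c2cc(=O)c3c(OC)cc(OC)cc3n2S(=O)(=O)c2ccc([N+](=O)[O-])cc2)cc1` gives > 29300 nM, a limit of this assay.
Compound 3 `COC(=O)c1cc(=O)c2cc(NC(=O)Nc3ccc(C(F)(F)F)cc3[N+](=O)[O-])ccc2[nH]1` gives > 25900 nM, which is also a limit of this assay.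

Compound 3 therefore stands at the edge of what this assay reports; its result is described by the limit of > 25900 nM in this assay, at which 1 of the 3 values shown sits. Compound 2 sits in the same position, its result being described by the limit of > 29300 nM in this assay, at which 1 of the 3 values shown sits. Going by the values given here, two of the three entries are thus limits and the third carries no number, so no measured step between two compounds exists here, and no change of this kind has yet been followed with a number on either side.

Compound 4 `COC(=O)c1cc(=O)c2cc(NC(=O)Nc3ccc(C(F)(F)F)cc3)ccc2[nH]1` differs from compound 3 in one place: hydrogen in place of nitro on an aromatic carbon. In words, a hydrogen takes the place of the nitro on an aromatic carbon of the six-membered carbon ring, ortho to a large group and meta to the trifluoromethyl group.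

With compound 3 at a limit, the step is expected to be none beyond the scatter, shown as a step that the limit leaves unreadable from compound 3 to compound 4. Compound 4 is accordingly expected to give 30000 nM, within a range from 6000 nM to 100000 nM, most likely again reported only as a limit.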

Compound 4, half-maximal effective concentration: > 6350 nM
Compound 4 was reported as a limit; the forecaster's own chance of this, stated with the estimate: 75%; the middle value does not contradict the limit.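

In this assay compound 3 gives > 25900 nM, which is a limit. Compound 4 gives > 6350 nM, also a limit. Going by these compounds alone, with both entries being limits, no step between compound 3 and compound 4 can be read. The compounds shown leave open whether hydrogen in place of nitro changes the result in this assay at all.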